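Removing the Dimethylaminopropyl Chain and Vero Cell Tolerance

The source may report more compounds than this note shows. Statements on the series, on what has been measured and on what is new or still open speak of the compounds shown alone.

Compound 1 `Fc1ccc(F)c(/N=N/Nc2ccccc2)c1` gives 80000 nM in an ADME assay on Vero cells (Chlorocebus sabaeus) for cytotoxicity, read by crystal violet staining; a higher number here means that more compound is tolerated, a lower number that less compound is tolerated.
Compound 2 `CN(C)CCCN(/N=N/c1cc(F)ccc1F)c1ccccc1` gives 7000 nM in this assay.
Compound 3 `CN(C)CCCN(/N=N/c1ccccc1)c1cccc(C(F)(F)F)c1` gives 20000 nM in this assay.

Compound 4 `FC(F)(F)c1cccc(N/N=N/c2ccccc2)c1` has not yet been measured in this assay. It arises from compound 3 by the change (hydrogen in place of 3-(dimethylamino)propyl on a nitrogen on an aromatic ring), and the same change, (hydrogen in place of 3-(dimethylamino)propyl on a nitrogen on an aromatic ring), carries compound 2 to compound 1, where it made an 11-fold higher number from compound 2 to compound 1 (1.06 log units; beyond the scatter). The difference between the cores of compound 3 and compound 2 is not broken down here. Within these compounds the change has one precedent, so the expectation rests on that single step: because that step was an 11-fold higher number from compound 2 to compound 1 (1.06 log units; beyond the scatter), a step of similar size is expected here, namely a 9.0-fold higher number from compound 3 to compound 4 (0.95 log units; beyond the scatter). Compound 4 is therefore estimated at 180000 nM, with a range from 60000 nM to 500000 nM.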

Compound 4, half-maximal cytotoxic concentration: 15000 nM
Beside the measured number, compound 4's estimate is 12-fold (1.08 log units) above it; the measured number lies below the stated range.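

On the core of compound 3, hydrogen in place of 3-(dimethylamino)propyl gave a 1.3-fold lower number from compound 3 to compound 4 (0.12 log units; within the scatter) in this assay, a result unlike the one seen earlier on the other core. The same change therefore behaved differently on the two cores: the same change on two cores in this assay, an 11-fold higher number (1.06 log units; beyond the scatter) from compound 2 to compound 1 and a 1.3-fold lower number (0.12 log units; within the scatter) from compound 3 to compound 4, 15-fold (1.18 log units) apart, beyond the scatter of two such steps This shows that the size of the step did not carry from one core to the other here, but it does not show which feature of the cores accounts for the difference, and two pairs give no general rule for the series.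

The compounds shown leave open which part of the cores separates the two steps. They also leave open how a shorter chain or a morpholine in place of the dimethylamino group would fare on either core.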